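Pyridin-3-yl in place of 1H-imidazol-1-yl: working estimate

This account rests on a few compounds, and the source may have more. Where it says the series, first, only, none or still open, it means among the compounds named here.

Measured in a functional assay on PC-3 cells (Homo sapiens) for antiproliferative activity, read by CCK-8 assay, with a stated time of 6 days; on this read-out lower numbers stand for stronger inhibition and higher numbers for weaker inhibition:
- compound 1 `CCN(c1ccc(C#N)c(Cl)c1)c1cc(-c2cncnc2)ccc1C`: > 30000 nM (a limit)
- compound 2 `CCN(c1ccc(C#N)c(Cl)c1)c1cc(-c2c[nH]nc2C)ccc1C`: 9030 nM
- compound 3 `CCN(c1ccc(C#N)c(Cl)c1)c1cc(-n2ccnc2)ccc1C`: > 30000 nM (a limit)

Compound 3 stands at > 30000 nM, which is a limit and not a number. Going by the values given here, compound 1 shares that position, and the series so far shows (the limit of > 30000 nM in this assay, at which 2 of the 3 values shown sit). Only compound 2 gives a number.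

The change to compound 4 `CCN(c1ccc(C#N)c(Cl)c1)c1cc(-c2cccnc2)ccc1C` is pyridin-3-yl in place of 1H-imidazol-1-yl on an aromatic carbon, with pyridin-3-yl in place of 1H-imidazol-1-yl on an aromatic carbon.

Among the compounds with values here, three measured steps bear on it, all at the same place. Going to 3-methyl-1H-pyrazol-4-yl gave an at least 3.3-fold lower number from compound 1 to compound 2 (0.52 log units; beyond the scatter), and going back to 1H-imidazol-1-yl gave an at least 3.3-fold higher number from compound 2 to compound 3 (0.52 log units; beyond the scatter), both beyond the scatter. The third, a step that the two limits leave unreadable from compound 1 to compound 3, cannot be sized. Replacing the group here has thus moved the number only modestly, and only for compound 2. In this assay a modest step at best is expected, towards a lower number, and another limit remains quite possible.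

The step expected is an at least 1.5-fold lower number from compound 3 to compound 4 (0.17 log units; that floor lies within the scatter) as estimated. For compound 4 the estimate is 20000 nM, with an expected range from 8000 nM to 40000 nM as its ends.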

Compound 4, half-maximal inhibitory concentration: 11000 nM
Beside the measured number, compound 4's estimate is 1.8-fold (0.26 log units) above it; low and high end bracket the measured number.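

In this assay, pyridin-3-yl in place of 1H-imidazol-1-yl gives an at least 2.7-fold lower number from compound 3 to compound 4 (0.43 log units; beyond the scatter), and pyridin-3-yl in place of pyrimidin-5-yl gives an at least 2.7-fold lower number from compound 1 to compound 4 (0.43 log units; beyond the scatter). A readable number at this place, on an aromatic carbon para to a methyl group, is therefore no longer confined to 3-methyl-1H-pyrazol-4-yl, and the five-membered and six-membered aromatic rings in question are not separated by this read-out, with a 1.2-fold higher number from compound 2 to compound 4 (0.09 log units; within the scatter). Compound 1 and compound 3 still stand only as limits, so the two steps from them give floors and not full sizes: the limit of > 30000 nM in this assay, at which 2 of the 4 values shown sit.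

From the compounds shown here alone, whether any group at this place can carry the number well beyond the level shared by compound 2 and compound 4 remains open, as does the outcome for an amine, a carboxylic acid or a longer chain in place of the aromatic ring. Also open, going by these compounds, is whether a methyl group on the pyridin-3-yl ring would shift the number beyond the scatter, or leave it level with compound 4.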